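Phenyl Directly on the Core in Place of 4-Methoxybenzyl

The source may hold more compounds than are shown below. What is called first, only, known or untested is meant among the compounds shown, and "the series" means these compounds.

Compound 1, `C=C(Br)C(=O)Nc1cccc(-c2cn3nc(-c4ccc(OC)c(OC)c4)sc3n2)c1`: 42 nM
Compound 2, `C=C(Br)C(=O)Nc1cccc(-c2cn3nc(CCc4ccccc4)sc3n2)c1`: 2200 nM
Compound 3, `C=C(Br)C(=O)Nc1cccc(-c2cn3nc(Cc4ccc(OC)cc4)sc3n2)c1`: 1400 nM

These three compounds share one core and were tested in a functional assay on L1210 cells (Mus musculus) for inhibition, read by cell counting, with a stated time of 2 days; on this read-out lower numbers stand for stronger inhibition and higher numbers for weaker inhibition. Compound 3 holds the second highest of the three numbers; its nearest neighbour is compound 2, at a step within the scatter, and its furthest is compound 1, at a step far beyond it.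

Compound 4, `C=C(Br)C(=O)Nc1cccc(-c2cn3nc(-c4ccccc4)sc3n2)c1`, differs from compound 3 in one place: phenyl in place of 4-methoxybenzyl on an aromatic carbon. The step that bears most on this change is a 33-fold higher number from compound 1 to compound 3 (1.52 log units; beyond the scatter), where a 3,4-dimethoxyphenyl on an aromatic carbon was replaced by a 4-methoxybenzyl. The step of a 52-fold higher number from compound 1 to compound 2 (1.72 log units; beyond the scatter) points the same way for phenethyl. Meanwhile a 1.6-fold lower number from compound 2 to compound 3 (0.20 log units; within the scatter), within the scatter, shows that the methoxy on the benzyl changed little. Compound 4 returns an aromatic ring to the aromatic carbon but lacks both methoxy groups of compound 1, so a large step toward a lower number, though not a full return to the number of compound 1, seems likely. For compound 4 the expected step is a 12-fold lower number from compound 3 to compound 4 (1.07 log units; beyond the scatter). Compound 4 is therefore estimated at 120 nM, with a range from 35 nM to 450 nM.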

Compound 4, half-maximal inhibitory concentration: 600 nM
Estimate against measurement, compound 4: 5.0-fold (0.70 log units) below; the whole stated range lies below it.
By their numbers in this assay, from the lowest: compound 1; then compound 4; then compounds 3 and 2 (each within the scatter of the next).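

Moving from 4-methoxybenzyl to a phenyl set directly on the aromatic carbon of the shared core gives, in this assay, a 2.3-fold lower number from compound 3 to compound 4 (0.37 log units; beyond the scatter), and replacing phenethyl with that phenyl gives a 3.7-fold lower number from compound 2 to compound 4 (0.56 log units; beyond the scatter); both steps are only modest. Adding the two methoxy groups to that phenyl is a far larger change, seen in reverse as a 14-fold higher number from compound 1 to compound 4 (1.15 log units; beyond the scatter). In the earlier compounds, the ring attached directly to the core and the pair of methoxy groups came and went together, whereas compound 4 pulls them apart: the direct attachment of a phenyl accounts for the smaller share of the distance to compound 1, and the step from phenyl to 3,4-dimethoxyphenyl accounts for the larger share.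

Nothing among the data shown explains why these groups shift the number in this way. From the compounds shown here alone, it also remains open whether a single methoxy on the directly attached phenyl would carry most of this gain, and how that ring would fare with an amine or a carboxylic acid in place of the methoxy groups.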